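The compounds below may be only part of what the source reports. "The series", "measured", "known", "first", "only" and "open" are said of these compounds alone.

Measured compounds:

Compound 1, `Cc1ccc(-c2ncccn2)c(C(=O)N2CC3(CC3)C[C@H]2CNc2ccc(Cl)cn2)c1`: in a functional assay on HEK293 cells for antagonist activity at Orexin receptor type 2 (Homo sapiens), read by FLIPR and calcium flux (a higher number here means a more potent compound, by a factor of ten per unit of this negative logarithm, a lower number a less potent compound), compound 1 gives < 5, which is a limit of the assay and not a number.
Compound 2, `Cc1ccc(-c2ncccn2)c(C(=O)N2CC3(CC3)C[C@H]2CNc2ccc(C(F)(F)F)cn2)c1`: compound 2 gives 6.6.
Compound 3, `Cc1nc(C(=O)N2CC3(CC3)C[C@H]2CNc2ccc(Cl)cn2)c(-c2ccccc2)s1`: compound 3 gives 7.1.

Going by the values given here, from compound 1 to compound 2 the only change is trifluoromethyl in place of chloro on an aromatic carbon. This brought a number at least 1.60 log units higher from compound 1 to compound 2 (beyond the scatter). The true size of that step is not pinned down, because the limit of < 5 in this assay, at which 1 of the 3 values shown sits, means the starting point is only known to lie at that limit.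

Compound 3 carries a different core; the difference between the core of compound 1 and the core of compound 3 is not broken down here. Compound 3 stands highest of the two numbers measured, and its number lies beyond the scatter from that of compound 2.

Compound 4, `Cc1nc(C(=O)N2CC3(CC3)C[C@H]2CNc2ccc(C(F)(F)F)cn2)c(-c2ccccc2)s1`, has not yet been measured. Among the compounds with values here, it differs from compound 3 by trifluoromethyl in place of chloro on an aromatic carbon, and this is the same change as the one made between compound 1 and compound 2, made at the same place. Within the data shown here, since compound 3 already gives 7.1, a gain as large as the one seen from compound 1 to compound 2 is not expected; a smaller rise is estimated instead. The expected step is a number 0.70 log units higher from compound 3 to compound 4 (beyond the scatter), resting on the direction of the earlier step of a number at least 1.60 log units higher from compound 1 to compound 2 (beyond the scatter). Compound 4 is therefore estimated at 7.8, likely between 7 and 8.6.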

Compound 4, negative logarithm of the antagonist equilibrium constant: 7.7
Estimate against measurement, compound 4: 0.10 log units above, within the range that was stated.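

In this assay, going from 5-chloropyridin-2-yl to 5-(trifluoromethyl)pyridin-2-yl on the core of compound 3 brought a number 0.60 log units higher from compound 3 to compound 4 (beyond the scatter), so the change raises the number on this core as it did on the core of compound 1, and its direction carries over between these two cores. Its size does not carry over, since the same swap gives a clearly smaller step here than on the first core: the same change on two cores in this assay, a number at least 1.60 log units higher (beyond the scatter) from compound 1 to compound 2 and a number 0.60 log units higher (beyond the scatter) from compound 3 to compound 4, at least 1.00 log units apart, beyond the scatter of two such steps. From the compounds shown here alone, the earlier step starts from compound 1, whose value is a limit and not a number, so the true size of that step and of the gap between the two steps stays unknown, and two cores alone do not establish a rule for the whole series: the limit of < 5 in this assay, at which 1 of the 4 values shown sits.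

The compounds shown contain only chloro and trifluoromethyl at this place on the ring, so it remains open how a nitrile or a methoxy group there would read on either core. Going by these compounds, it is also open whether the swap from chloro to trifluoromethyl would again raise the number on a third core, and by how much.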